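Lengthening the linker chain from compound 2 to compound 3

This account rests on a few compounds, and the source may have more. Where it says the series, first, only, none or still open, it means among the compounds named here.

Compound 2 `CN(C)C(=O)c1cc2cnc(Nc3ccc(C(=O)NCCCCCN=C=S)cc3)nc2n1C1CCCC1` is the weaker of the two measured compounds: in a functional assay on A549 cells (Homo sapiens) for inhibition, read by CCK-8 assay, with a stated time of 72 h, tested at 1 uM (a higher number here means a stronger effect of the compound at the concentration tested, a lower number a weaker effect), compound 2 gives 29.3%, the lowest of the two numbers. Compound 1 `CN(C)C(=O)c1cc2cnc(Nc3ccc(S(=O)(=O)NCCCCCN=C=S)cc3)nc2n1C1CCCC1` stands nearest; in this assay compound 1 gives 56.6%, and the step of a number 27.3 percentage points lower from compound 1 to compound 2 (beyond the scatter) lies beyond the scatter. That step swaps the group on the aromatic carbon and leaves the chain untouched, so it does not bear directly on the change now in view. Compound 3 `CN(C)C(=O)c1cc2cnc(Nc3ccc(C(=O)NCCCCCCN=C=S)cc3)nc2n1C1CCCC1` differs from compound 2 by a group of 4 heavy atoms (2 carbon, 1 nitrogen, 1 sulfur; no ring) in place of a group of 3 heavy atoms (1 carbon, 1 nitrogen, 1 sulfur; no ring), on a saturated chain carbon, five bonds along the chain from an amide-type nitrogen. Going by the values given here, no measured pair varies the chain, so there is no step from which to read a direction or a size; the working expectation is a step of a number 0.7 percentage points higher from compound 2 to compound 3 (within the scatter), which is not expected to go beyond the scatter. Compound 3 is therefore estimated at 30%, with a range from 15% to 48%.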

Compound 3, a percentage reported as inhibition, at one concentration (the size of the read-out at that concentration, not a potency): 35.8%
Compound 3: middle estimate off by 5.8 percentage points, on the low side; measured number inside the range.
By their numbers in this assay, from the lowest: compounds 2 and 3 (each within the scatter of the next); then compound 1.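

Notes on the chain: in this assay the series now has its first reading of chain length on the carbonyl-linked side, and the group of 4 heavy atoms in place of the group of 3 heavy atoms, on a saturated chain carbon, gives a step that stays within the scatter (a number 6.5 percentage points higher from compound 2 to compound 3 (within the scatter)). The added chain carbon does not bring this compound level with the compound carrying the other group on the aromatic carbon (a number 20.8 percentage points lower from compound 1 to compound 3 (beyond the scatter)), so that step remains beyond the scatter at this chain length as well. No measurement is at hand that bears on the reason for either step.

As far as these compounds go, whether a longer chain would keep the reading flat in this assay remains open, as does the effect of the same chain extension on compound 1. An amine in place of the entering group, on the same saturated chain carbon, would show how much the reading depends on that group.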